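The compounds below may be only part of what the source reports. "The series", "measured", "known", "first", "only" and "open" are said of these compounds alone.

Compound 2 `CC1(C)c2cc(Cl)ccc2C(=O)N1c1cncc(CNS(C)(=O)=O)c1` is the stronger of the two measured compounds: in an assay on cells for inhibition of cytochrome P450 11B2, mitochondrial (Homo sapiens), read by HTRF (a higher number here means a weaker inhibitor, a lower number a stronger inhibitor), compound 2 gives 33 nM, while compound 1 `CCC(=O)NCc1cncc(N2C(=O)c3ccc(Cl)cc3C2(C)C)c1` gives 282 nM. Among the compounds with values here, the one measured step, an 8.5-fold lower number from compound 1 to compound 2 (0.93 log units; beyond the scatter), concerns only the group on the amine nitrogen. Compound 3 `C[C@@H](NS(C)(=O)=O)c1cncc(N2C(=O)c3ccc(Cl)cc3C2(C)C)c1` differs from compound 2 in another place: methyl in place of hydrogen on a saturated chain carbon bound to an aromatic carbon and a sulfonamide nitrogen. Within the data shown here, no measured step touches that carbon, so the step in this assay is expected to be small, in either direction or none beyond the scatter. Compound 3 is therefore estimated at 40 nM, within 15 nM to 120 nM, a step of a 1.2-fold higher number from compound 2 to compound 3 (0.08 log units; within the scatter).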

Compound 3, half-maximal inhibitory concentration: 8 nM
Beside the measured number, compound 3's estimate is 5.0-fold (0.70 log units) above it; the measured number lies below the stated range.
By their numbers in this assay, from the lowest: compound 3; then compound 2; then compound 1.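

On the saturated chain carbon bound to an aromatic carbon and a sulfonamide nitrogen, methyl in place of hydrogen lowers the number in this assay (a 4.1-fold lower number from compound 2 to compound 3 (0.62 log units; beyond the scatter)), so this carbon, untouched by the earlier pair, also bears on the read-out. With the sulfonamide and this methyl together, the whole side group gives a larger change (a 35-fold lower number from compound 1 to compound 3 (1.55 log units; beyond the scatter)). Nothing at hand explains either step. Still open, from the compounds shown here alone, are the opposite configuration at this carbon and whether ethyl or cyclopropyl there would lower the number further.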